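This account rests on a few compounds, and the source may have more. Where it says the series, first, only, none or still open, it means among the compounds named here.

Of the three compounds measured in a functional assay on KU812 cells (Homo sapiens) for antiproliferative activity (a higher number here means a weaker inhibitor, a lower number a stronger inhibitor), compound 3 `Cc1cn(-c2cc(NC(=O)c3ccc(C)c(Nc4nc(-c5cccnc5)cs4)c3)cc(C(C)C)c2)cn1` stands lowest: in this assay compound 3 gives 51 nM, while compound 2 `Cc1cc(NC(=O)c2ccc(C)c(Nc3nc(-c4cccnc4)cs3)c2)cc(-n2cnc(C)c2)c1` gives 871 nM and compound 1 `Cc1ccc(C(=O)Nc2cccc(C(F)(F)F)c2)cc1Nc1nc(-c2cccnc2)cs1` gives 1240 nM. Among the measured compounds shown here, the only single-point step among them, a 17-fold lower number from compound 2 to compound 3 (1.23 log units; beyond the scatter), came from isopropyl in place of methyl on an aromatic carbon and lies well beyond the scatter.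

Compound 4 `Cc1cn(-c2cc(Cl)cc(NC(=O)c3ccc(C)c(Nc4nc(-c5cccnc5)cs4)c3)c2)cn1` differs from compound 3 by chloro in place of isopropyl on an aromatic carbon. For the measured compounds named here, no measured pair shows chloro entering at that position, so the step from compound 2 to compound 3 is the only one that bears on it, and only indirectly: it shows that the group at this carbon matters a great deal in this assay, with a larger group giving the lower number. Chloro is smaller than isopropyl by the count above, so compound 4 is expected to give a higher number than compound 3, by a step of about a 3.5-fold higher number from compound 3 to compound 4 (0.55 log units; beyond the scatter), though probably not returning all the way to compound 2. The estimate for compound 4 in this assay is therefore 180 nM, with a range from 50 nM to 600 nM.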

Compound 4, half-maximal inhibitory concentration: 518 nM
The estimate for compound 4 lay 2.9-fold (0.46 log units) below the measured number; the measured number falls inside the stated range.
By their numbers in this assay, from the lowest: compound 3; then compounds 4, 2 and 1 (each within the scatter of the next, the first and the last beyond it).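

In this assay the exchange of isopropyl for chloro on this aromatic carbon gives a 10-fold higher number from compound 3 to compound 4 (1.01 log units; beyond the scatter) and so removes the low number of compound 3, which the earlier step had tied only to isopropyl against methyl. Chloro and methyl are not separated here, with a 1.7-fold lower number from compound 2 to compound 4 (0.23 log units; within the scatter) as the only step between them, so among these three groups isopropyl alone stands apart, rather than chloro falling midway between the other two. Nothing measured here explains this difference.

The compounds shown leave open whether the low number needs isopropyl itself or would also be reached with ethyl, cyclopropyl or tert-butyl at this carbon. They also leave open how a longer chain or an amine would fare there.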